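Chloro on the core of a weakly cytotoxic oxindole-indole series

This account rests on a few compounds, and the source may have more. Where it says the series, first, only, none or still open, it means among the compounds named here.

Compound 1 `O=C1Nc2ccccc2/C1=C\c1c(Cl)n(Cc2ccccc2)c2ccccc12` and compound 2 `O=C1Nc2ccccc2/C1=C\c1c(Cl)n(CCCc2ccccc2)c2ccccc12` share one core and differ only in the chain on the ring nitrogen. In a functional assay on cells (Cancer cell lines, Homo sapiens) for cytotoxicity, with a stated time of 48 h (on this read-out lower numbers stand for stronger inhibition of growth and higher numbers for weaker inhibition of growth), compound 1 gives 60300 nM, and compound 2 gives 60300 nM. The step of no change at the digits printed from compound 1 to compound 2 (within the scatter) shows that lengthening that chain did not move the read-out. For the measured compounds named here, compound 2 therefore stands level with compound 1 on the numbers so far.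

Compound 3 `O=C1Nc2ccc(Cl)cc2/C1=C\c1c(Cl)n(CCCc2ccccc2)c2ccccc12` differs from compound 2 in chloro in place of hydrogen on an aromatic carbon. Going by the values given here, this change sits on the shared core, far from the chain that was varied, so the one measured step does not speak to it. With no step of this kind in hand, the expected outcome is a step of a 1.0-fold lower number from compound 2 to compound 3 (0.00 log units; within the scatter) that stays within the scatter. Compound 3 is estimated to give 60000 nM in this assay, with a likely range from 20000 nM to 150000 nM.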

Compound 3, concentration for total growth inhibition: 5620 nM
Compound 3: the middle estimate sits 11-fold (1.03 log units) above what was measured; measured number outside the range, below it.
By their numbers in this assay, from the lowest: compound 3; then compounds 1 and 2 (each within the scatter of the next).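

In this assay, chloro in place of hydrogen on an aromatic carbon of the shared core gives an 11-fold lower number from compound 2 to compound 3 (1.03 log units; beyond the scatter), whereas the change to the chain on the ring nitrogen gave no change at the digits printed from compound 1 to compound 2 (within the scatter). This position on the core can therefore move the read-out, even though the change replaces only a hydrogen and adds no ring and no hydrogen-bond donor or acceptor. Nothing available explains the size of this step.

As far as these compounds go, it remains open whether chloro is special at this position or whether another group there, such as methoxy, an amine or a nitrile, would give a similar step. From the compounds shown here alone, it is also open whether chloro at the same place would give a step of this size with the chain of compound 1.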